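Benzyl ether truncation to methyl ether in the chromanone series

The compounds below may be only part of what the source reports. "The series", "measured", "known", "first", "only" and "open" are said of these compounds alone.

Compound 1 `O=C1CC(c2ccccc2OCc2ccccc2)Oc2ccccc21` gives 18900 nM in a functional assay on RAW264.7 cells (Mus musculus) for inhibition, read by Griess assay, with stated times of 1 h and 24 h; on this read-out lower numbers stand for stronger inhibition and higher numbers for weaker inhibition. Compound 2 `O=C1CC(c2ccccc2OCc2cccc(F)c2)Oc2ccccc21` gives 15600 nM, and compound 3 `O=C1CC(c2ccccc2OCc2ccc(F)cc2)Oc2ccccc21` gives 28200 nM; compound 3 holds the highest of the three numbers, though the steps of a 1.5-fold higher number from compound 1 to compound 3 (0.17 log units; within the scatter) and a 1.8-fold higher number from compound 2 to compound 3 (0.26 log units; within the scatter) are both within the scatter, as is a 1.2-fold lower number from compound 1 to compound 2 (0.08 log units; within the scatter). Compound 4 `COc1ccccc1C1CC(=O)c2ccccc2O1` differs from compound 3 by hydrogen in place of 4-fluorophenyl on a saturated chain carbon bound to an oxygen on an aromatic ring. Within the data shown here, no measured step removes the whole 4-fluorophenyl; the steps seen only move or add fluorine and stay within scatter, so they give no direction for this larger change. Compound 4 is therefore expected near compound 3, with wide uncertainty, as a 1.2-fold higher number from compound 3 to compound 4 (0.09 log units; within the scatter). The estimate for compound 4 is 35000 nM, between 9000 nM and 120000 nM.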

Compound 4, half-maximal inhibitory concentration: 47300 nM
Compound 4: the middle estimate sits 1.4-fold (0.13 log units) below what was measured, within the range that was stated.
By their numbers in this assay, from the lowest: compounds 2, 1, 3 and 4 (each within the scatter of the next, the first and the last beyond it).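

Truncating the benzyl ether to the methyl ether gives the only steps in the series that pass the scatter in this assay, both against the unsubstituted and 3-fluorophenyl ethers (a 2.5-fold higher number from compound 1 to compound 4 (0.40 log units; beyond the scatter); a 3.0-fold higher number from compound 2 to compound 4 (0.48 log units; beyond the scatter)). Against the 4-fluorophenyl ether, the same truncation stays within the scatter (a 1.7-fold higher number from compound 3 to compound 4 (0.22 log units; within the scatter)), so the aryl group counts for only a modest part of the read-out, and not against every benzyl ether. No supporting data bear on this change.

Still open, from the compounds shown here alone, is whether a propyl chain or a chain ending in an amine, in place of the aryl group, would return the numbers to those of the benzyl ethers.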